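This account rests on a few compounds, and the source may have more. Where it says the series, first, only, none or still open, it means among the compounds named here.

Compound 2 `CCCS(=O)(=O)Nc1ccc(F)c(C(=O)c2n[nH]c3ncc(-c4ccc(C)cc4)cc23)c1F`: 5.4%
Compound 1 `CCCS(=O)(=O)Nc1ccc(F)c(C(=O)c2n[nH]c3ncc(-c4ccccc4Cl)cc23)c1F`: 9.3%
Compound 3 `CCCS(=O)(=O)Nc1ccc(F)c(C(=O)c2n[nH]c3ncc(-c4ccc(Cl)cc4Cl)cc23)c1F`: 22%

In an assay for binding affinity to dual specificity mitogen-activated protein kinase kinase 4 (Homo sapiens), read by KINOMEscan, tested at 100 nM (on this read-out higher numbers stand for a weaker effect at the one concentration tested and lower numbers for a stronger effect), compound 2 gives the lowest number of the three: compound 1 sits within the scatter of it, compound 3 beyond it, a number 16.6 percentage points higher from compound 2 to compound 3 (beyond the scatter). Compound 4 `CCCS(=O)(=O)Nc1ccc(F)c(C(=O)c2n[nH]c3ncc(-c4cccc([N+](=O)[O-])c4)cc23)c1F` carries 3-nitrophenyl in place of 4-methylphenyl on an aromatic carbon. Going by the values given here, no measured step introduces a nitro group, so the steps that bear on it are indirect: a number 3.9 percentage points lower from compound 1 to compound 2 (within the scatter) and a number 16.6 percentage points higher from compound 2 to compound 3 (beyond the scatter), with a number 12.7 percentage points higher from compound 1 to compound 3 (beyond the scatter) pointing the same way. Changes on this ring have so far left the number where it was or raised it modestly. For compound 4 a modest rise is expected, a number 6.6 percentage points higher from compound 2 to compound 4 (within the scatter), with a shift beyond the scatter in either direction not excluded. Compound 4 is expected at 12%, range 3% to 30%.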

Compound 4, a percentage reported as activity, at one concentration (the size of the read-out at that concentration, not a potency): 15%
Compound 4: the middle estimate sits 3 percentage points below what was measured, and the stated range covers the measured number.
By their numbers in this assay, from the lowest: compounds 2, 1, 4 and 3 (each within the scatter of the next, the first and the last beyond it).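

In this assay, 3-nitrophenyl brings hydrogen-bond acceptors to this position, yet a number 9.6 percentage points higher from compound 2 to compound 4 (within the scatter) and a number 5.7 percentage points higher from compound 1 to compound 4 (within the scatter) and a number 7 percentage points lower from compound 3 to compound 4 (within the scatter) all stay within the scatter. Compound 4 thus separates from none of the other three compounds, while compounds 2 and 3 remain apart beyond the scatter. No measurement shown here accounts for these numbers. On these data alone, whether an amine or a carboxylic acid in place of the nitro group would leave the number within the scatter of compound 4 stays open.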